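A Fluorine Added to the Phenyl Ring of Compound 3

The source may hold more compounds than are shown below. What is called first, only, known or untested is meant among the compounds shown, and "the series" means these compounds.

Of the compounds shown here, three sharing one core have been tested in a functional assay on NCI-H460 cells (Homo sapiens) for cytotoxicity, read by MTT assay, with a stated time of 72 h; a higher number here means a weaker inhibitor, a lower number a stronger inhibitor. Compound 1 `COc1cc2c(Oc3ccc(NC(=O)c4cc(-c5ccccc5C)ccn4)cc3F)ccnc2cc1OCCCN1CCCC1` gives 420 nM. Compound 2 `COc1cc2c(Oc3ccc(NC(=O)c4cc(-c5ccccc5)ccn4)cc3F)ccnc2cc1OCCCN1CCCCC1` gives 120 nM. Compound 3 `COc1cc2c(Oc3ccc(NC(=O)c4nccc(-c5ccccc5)n4)cc3F)ccnc2cc1OCCCN1CCCCC1` gives 330 nM. Among these numbers compound 3 stands second highest: it and compound 1 lie within the scatter of each other, while the gap to compound 2 is beyond it, as the step of a 2.8-fold higher number from compound 2 to compound 3 (0.44 log units; beyond the scatter) shows.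

Compound 4 `COc1cc2c(Oc3ccc(NC(=O)c4nccc(-c5ccc(F)cc5)n4)cc3F)ccnc2cc1OCCCN1CCCCC1` differs from compound 3 in one place: fluoro in place of hydrogen on an aromatic carbon. Within the data shown here, no measured step covers this change. Among the measured compounds shown here, the only recorded step, a 2.8-fold higher number from compound 2 to compound 3 (0.44 log units; beyond the scatter), concerns a different ring and says nothing about a fluorine on the phenyl ring. Compound 1 and compound 2 differ in two places at once, so their values cannot be read as a single step. With no guide in the data, the step is expected to be no change at the digits printed from compound 3 to compound 4 (within the scatter), none beyond the scatter. Compound 4 is therefore estimated at 330 nM, within a range from 150 nM to 720 nM.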

Compound 4, half-maximal inhibitory concentration: 240 nM
Compound 4: the middle estimate sits 1.4-fold (0.14 log units) above what was measured, within the range that was stated.
By their numbers in this assay, from the lowest: compounds 2, 4, 3 and 1 (each within the scatter of the next, the first and the last beyond it).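

In this assay, exchanging phenyl for 4-fluorophenyl gives a 1.4-fold lower number from compound 3 to compound 4 (0.14 log units; within the scatter). Among these compounds, this is the first reading at this place, on an aromatic carbon para to a large group, and it shows that a single fluoro here leaves the number indistinguishable from that of the unsubstituted phenyl ring, given the usual scatter of the assay. Nothing available offers a reason for this outcome, so the result stands as an observation only.

Going by these compounds, a single small atom says little about what this place accepts, so it remains open whether a methoxy group, an amine or a carboxylic acid at the same carbon would give a step beyond the scatter. On these data alone, it is also open whether the same fluoro on the phenyl ring of compound 2 would give a similar step.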